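Piperidine for methylpiperazine on the dichlorophenyl purine series

The compounds below may be only part of what the source reports. "The series", "measured", "known", "first", "only" and "open" are said of these compounds alone.

Of the compounds shown here, three carry numbers so far. Compound 1 `CN1CCN(c2nc(-c3ccc(Cl)c(Cl)c3)nc3[nH]cnc23)CC1` in an assay on cells for displacement of a labelled ligand from adenosine receptor A2b (Homo sapiens), read by scintillation counting and radioligand binding, with a stated time of 30 min, tested at 10 uM (on this read-out lower numbers stand for less inhibition and higher numbers for more inhibition at the one concentration tested (going by the name of the read-out)), gives 24.1%. Compound 2 `Clc1ccc(-c2nc(N3CCCCC3)c3nc[nH]c3n2)cc1Cl` in this assay gives 0.7%. Compound 3 `CN1CCN(c2nc(-c3cc(Cl)ccc3Cl)nc3[nH]cnc23)CC1` in this assay gives 13%, the second highest of the three. Compound 4 `Clc1ccc(Cl)c(-c2nc(N3CCCCC3)c3nc[nH]c3n2)c1` is not yet measured.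

Compound 1 and compound 3 differ only in their cores: 2,5-dichlorophenyl in place of 3,4-dichlorophenyl on an aromatic carbon. This rearrangement gives a number 11.1 percentage points lower from compound 1 to compound 3 (beyond the scatter).

The change piperidin-1-yl in place of 4-methylpiperazin-1-yl on an aromatic carbon gives a number 23.4 percentage points lower from compound 1 to compound 2 (beyond the scatter). Compound 4 is made from compound 3 by the same kind of change, (piperidin-1-yl in place of 4-methylpiperazin-1-yl on an aromatic carbon); the surroundings differ in that the replaced group stands meta to a 2,5-dichlorophenyl group rather than meta to a 3,4-dichlorophenyl group.

The expectation for compound 4 rests on one prior instance of the change, compound 1 to compound 2, where the drop of a number 23.4 percentage points lower from compound 1 to compound 2 (beyond the scatter) carried compound 2 down to near the bottom of the read-out at 0.7%. Starting from the lower number of compound 3, the same kind of change cannot fall by the same amount, so the expected step in this assay is a number 11 percentage points lower from compound 3 to compound 4 (beyond the scatter). For compound 4 an estimated 2% is expected, with a likely range from -5% to 10%.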

Compound 4, a percentage reported as inhibition, at one concentration (the size of the read-out at that concentration, not a potency): 12.1%
Estimate against measurement, compound 4: 10.1 percentage points below; the measured number lies above the stated range.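

In this assay, piperidin-1-yl in place of 4-methylpiperazin-1-yl on the 2,5-dichlorophenyl compound gives a number 0.9 percentage points lower from compound 3 to compound 4 (within the scatter), so on this core the change leaves no readable difference. The change therefore does not carry over with one size from the core of compound 1 to the core of compound 3: the same change on two cores in this assay, a number 23.4 percentage points lower (beyond the scatter) from compound 1 to compound 2 and a number 0.9 percentage points lower (within the scatter) from compound 3 to compound 4, 22.5 percentage points apart, beyond the scatter of two such steps. Among the compounds shown here, this rests on only two matched pairs, each read as inhibition at one concentration, so it shows that the size of the step depended on the core here, but it gives no cause for that dependence, no potency and no rule for any further core.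

Still open, as far as these compounds go, is how another amine at the same place, such as morpholin-4-yl or piperazin-1-yl with a free ring nitrogen, would behave on these two cores. Also open, from the compounds shown here alone, is whether a third aryl group, such as an unsubstituted phenyl or a 3,5-dichlorophenyl, would follow either of the two steps.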